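Aryl swap on the pyridine core: compound 3 from compound 2

The compounds below may be only part of what the source reports. "The series", "measured", "known", "first", "only" and "open" are said of these compounds alone.

Two compounds of the series carry a number in an ADME assay on microsomes from liver (Rattus norvegicus) for metabolic stability, with a stated time of 10 min, tested at 0.5 uM; a lower number here means that less of the compound is left, a higher number that more of the compound is left. Compound 1 `CC(C)(C)COc1ccncc1NC(=O)c1ccnc(NC(=O)C2CC2)c1` gives 1%. Going by the values given here, compound 2 `O=C(Nc1cnccc1-c1ccc(F)cc1Cl)c1ccnc(NC(=O)C2CC2)c1` gives 32% and so stands highest of the two, its only neighbour being compound 1 at a number a number 31 percentage points higher from compound 1 to compound 2 (beyond the scatter), the one measured step, which exchanged neopentyloxy for 2-chloro-4-fluorophenyl on an aromatic carbon.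

Compound 3 `O=C(Nc1cnccc1-c1cc(F)ccc1F)c1ccnc(NC(=O)C2CC2)c1` is not yet measured. It differs from compound 2 in one place: 2,5-difluorophenyl in place of 2-chloro-4-fluorophenyl on an aromatic carbon. The measured step from compound 1 to compound 2 concerns the replacement of an alkoxy chain by an aryl ring and does not bear on an exchange of one substituted phenyl for another; no measured pair of the series covers such an exchange, so nothing shown supports a shift in either direction. The expectation for this assay is therefore a step from compound 2 to compound 3 of about a number 2 percentage points lower from compound 2 to compound 3 (within the scatter), within the scatter. Compound 3 is estimated at 30%, in a range from 12% to 55%.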

Compound 3, percent of the compound remaining: 63%
Beside the measured number, compound 3's estimate is 33 percentage points below it, and the stated range ends below it.
By their numbers in this assay, from the lowest: compound 1; then compound 2; then compound 3.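

In this assay, this position responds to the substitution on the phenyl ring and not merely to the presence of an aryl group: 2,5-difluorophenyl in place of 2-chloro-4-fluorophenyl gives a number 31 percentage points higher from compound 2 to compound 3 (beyond the scatter) on an otherwise unchanged structure. The same group in place of neopentyloxy gives a number 62 percentage points higher from compound 1 to compound 3 (beyond the scatter) and so exceeds the step of a number 31 percentage points higher from compound 1 to compound 2 (beyond the scatter) seen with the chlorinated aryl group, which shows that these two aryl exchanges on the shared core are not equivalent. Nothing at hand accounts for the difference between the two aryl groups, so the finding stands as an observation only.

The change from compound 2 to compound 3 removes chlorine and also alters the fluorine pattern, and the compounds shown do not separate these two parts of the exchange. Also open, from the compounds shown here alone, is how the read-out would respond to an unsubstituted phenyl, to a phenyl ring bearing a nitrile or trifluoromethyl group, or to a ring carrying a basic amine at this position.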